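This account rests on a few compounds, and the source may have more. Where it says the series, first, only, none or still open, it means among the compounds named here.

All numbers here come from a functional assay on muscle tissue for agonist activity at histamine H2 receptor (Cavia porcellus); on this read-out higher numbers stand for higher potency (the scale is a negative logarithm) and lower numbers for lower potency.

Measured compounds:
compound 1 `N=C(NCCCc1c[nH]cn1)NCCC(c1ccccc1)c1ccccn1`: 7.37
compound 2 `Cc1ccc(C(CC/N=C(\N)NCCCc2c[nH]cn2)c2ccccn2)cc1`: 7.15
compound 3 `N=C(NCCCc1c[nH]cn1)NCCC(c1ccc(Cl)cc1)c1ccccn1`: 7.39

Compound 3 carries the highest of the three numbers, but compound 1 and compound 2 both sit within the scatter of it, so the three are not separated. Compound 4 `N=C(NCCCc1c[nH]cn1)NCCC(c1ccc(Br)cc1)c1ccccn1` differs from compound 3 by bromo in place of chloro on an aromatic carbon. Among the measured compounds shown here, the only measured step touching this position is a number 0.02 log units higher from compound 1 to compound 3 (within the scatter), which stayed within the scatter; no measured pair sets chloro against bromo. Since putting a halogen onto that carbon changed nothing measurable, the exchange of one halogen for another is expected to give no step beyond the scatter, a number 0.01 log units higher from compound 3 to compound 4 (within the scatter). Compound 4 is therefore expected to give 7.4 in this assay, with a range from 7 to 7.8.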

Compound 4, negative logarithm of the half-maximal effective concentration: 6.97
Compound 4: middle estimate off by 0.43 log units, on the high side; measured number outside the range, below it.
By their numbers in this assay, from the lowest: compounds 4, 2, 1 and 3 (each within the scatter of the next, the first and the last beyond it).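

In this assay the position is not indifferent to the halogen: there is a number 0.42 log units lower from compound 3 to compound 4 (beyond the scatter) and, against the unsubstituted ring, a number 0.40 log units lower from compound 1 to compound 4 (beyond the scatter) for bromo. Chloro, with a number 0.02 log units higher from compound 1 to compound 3 (within the scatter) as its step, and bromo therefore cannot be treated as interchangeable on this carbon. Nothing available bears on the reason for this difference and the step stands as an observation only.

On these data alone, what fluoro, iodo or methoxy would give on this carbon remains open. Also open, as far as these compounds go, is whether the lower number with bromo persists with a shorter or longer chain.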